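The source may report more compounds than this note shows. Statements on the series, on what has been measured and on what is new or still open speak of the compounds shown alone.

Compound 2 `COc1cccc(S(=O)(=O)Nc2ccc3oc(-c4ccccc4)nc3c2)c1` was tested in an ADME assay on HEK293 cells (Homo sapiens) for cytotoxicity, read by resazurin assay, with a stated time of 48 h (a lower number here means that less compound is tolerated, a higher number that more compound is tolerated), and gives 63000 nM. Compound 1 `O=S(=O)(Nc1ccc(-c2nc3ccccc3o2)cc1)c1ccc(F)c(C(F)(F)F)c1` gives 82000 nM in this assay, and the two values lie within the usual scatter of one another, so they cannot be told apart. Compound 3 `O=S(=O)(Nc1ccc2oc(-c3ccccc3)nc2c1)c1ccc(Cl)c(Cl)c1` has not yet been measured. It differs from compound 2 in one place: 3,4-dichlorophenyl in place of 3-methoxyphenyl on a sulfonyl sulfur. Within the data shown here, no measured pair shows what this change does in this assay. The expected step is a 1.4-fold lower number from compound 2 to compound 3 (0.15 log units; within the scatter), small and toward less compound tolerated. Compound 3 is estimated at 45000 nM, with a range from 15000 nM to 100000 nM.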

Compound 3, half-maximal cytotoxic concentration: 71000 nM
Beside the measured number, compound 3's estimate is 1.6-fold (0.20 log units) below it, and the stated range covers the measured number.
By their numbers in this assay, from the lowest: compounds 2, 3 and 1 (each within the scatter of the next).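

Among these compounds, putting 3,4-dichlorophenyl in place of 3-methoxyphenyl on a sulfonyl sulfur gives a 1.1-fold higher number from compound 2 to compound 3 (0.05 log units; within the scatter) in this assay and is the first measured one-place change at this position. In this single pair, the two aryl groups cannot be told apart, so this change leaves no readable effect on the number. Nothing measured here offers an explanation for this result. From the compounds shown here alone, whether an amine or a carboxylic acid on this ring would also leave the number unchanged remains open, as does whether the same holds on the core of compound 1.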